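Cytotoxicity notes: aryl in place of cycloalkyl

The compounds below may be only part of what the source reports. "The series", "measured", "known", "first", "only" and "open" are said of these compounds alone.

The series shares one core, seen in compound 1 `C[C@]1(CN2CCc3nc(-c4ccc(F)cc4)nnc3C2)Cn2cc([N+](=O)[O-])nc2O1`, compound 2 `C[C@]1(CN2CCc3nc(-c4ccc(F)cc4)sc3C2)Cn2cc([N+](=O)[O-])nc2O1` and compound 3 `C[C@]1(CN2CCc3nc(C4CCCCC4)ccc3C2)Cn2cc([N+](=O)[O-])nc2O1`; the three differ only in the group carried by the fused bicyclic amine. In an ADME assay on Vero cells (Chlorocebus sabaeus) for cytotoxicity, read by MTT assay, with a stated time of 72 h (a lower number here means that less compound is tolerated, a higher number that more compound is tolerated), compound 1 gives "not determined" (no result reported). In this assay compound 2 reaches only a limit, > 32 ug/mL, and no number beyond it. In this assay compound 3 gives "not determined" (no result reported) as well, so compound 3 has no number of its own to stand on. Of the three entries, one is a limit, at the limit of > 32 ug/mL in this assay, at which 1 of the 3 values shown sits, and the other two are empty.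

Compound 4 `C[C@]1(CN2CCc3nc(-c4ccc(F)c(F)c4)ccc3C2)Cn2cc([N+](=O)[O-])nc2O1` follows compound 3 by one change: 3,4-difluorophenyl in place of cyclohexyl on an aromatic carbon. Among the measured compounds shown here, the step has no measured counterpart in the set, and no step between measured compounds is available at all, so nothing in this assay says whether the change should move the number; the expectation is of a step no larger than the scatter, in no fixed direction. With compound 2 sitting at a limit, compound 4 is estimated in this assay at 32 ug/mL, expected between 16 ug/mL and 64 ug/mL, with a fair chance that only a limit is returned.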

Compound 4, half-maximal cytotoxic concentration: > 32 ug/mL
Compound 4 gave a limit, no number; the forecaster's own chance of this, stated with the estimate: 70%; the middle value sits exactly at the limit.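

Compound 4 returns only a limit in this assay, > 32 ug/mL, and compound 3 has no number, so no step can be read between compound 3 and compound 4. The compounds shown leave open whether 3,4-difluorophenyl and cyclohexyl differ at all in this assay, and where any compound's actual value lies.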